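The compounds below may be only part of what the source reports. "The series", "measured", "known", "first", "only" and "open" are said of these compounds alone.

In a functional assay on MCF7 cells (Homo sapiens) for antiproliferative activity, read by MTT assay, with a stated time of 48 h (on this read-out higher numbers stand for weaker inhibition and lower numbers for stronger inhibition), compound 1 `Cc1ccc(C(=O)/C=C/c2cccc(Br)c2Oc2c([N+](=O)[O-])cc(C(F)(F)F)cc2[N+](=O)[O-])cc1` gives 0.55 ug/mL, while compound 2 `O=C(/C=C/c1cc(Br)cc(Br)c1Oc1c([N+](=O)[O-])cc(C(F)(F)F)cc1[N+](=O)[O-])c1ccc(F)cc1` gives 8.06 ug/mL, the higher of the two numbers by a gap beyond the usual scatter. Compound 3 `O=C(/C=C/c1cccc(Br)c1Oc1c([N+](=O)[O-])cc(C(F)(F)F)cc1[N+](=O)[O-])c1ccc(F)cc1` departs from compound 2 at one place: hydrogen in place of bromo on an aromatic carbon. Within the data shown here, no measured pair shows this change alone, so the forecast rests on little. Among the measured compounds shown here, the only other number, 0.55 ug/mL for compound 1, lies lower, so a move toward stronger inhibition is expected. The expected step is a 5.4-fold lower number from compound 2 to compound 3 (0.73 log units; beyond the scatter), beyond the scatter. For compound 3 the estimate is 1.5 ug/mL, with an expected range of 0.4 ug/mL to 6 ug/mL.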

Compound 3, half-maximal inhibitory concentration: 6.01 ug/mL
The estimate for compound 3 lay 4.0-fold (0.60 log units) below the measured number, and the stated range ends below it.
By their numbers in this assay, from the lowest: compound 1; then compounds 3 and 2 (each within the scatter of the next).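

Hydrogen in place of bromo at this position, meta to a bromo group, gives a 1.3-fold lower number from compound 2 to compound 3 (0.13 log units; within the scatter) in this assay, so this bromo can go without a change beyond the usual scatter. Fluoro in place of methyl on an aromatic carbon gives an 11-fold higher number from compound 1 to compound 3 (1.04 log units; beyond the scatter), so the large gap seen earlier between compound 1 and compound 2 goes with that change and not with this bromo. Nothing at hand explains either step.

As far as these compounds go, whether this position accepts anything larger or different, such as an amine or a carboxylic acid, stays open. So does whether a chloro or methoxy group on that aromatic carbon would match the methyl of compound 1 or the fluoro of compound 3.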